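This account rests on a few compounds, and the source may have more. Where it says the series, first, only, none or still open, it means among the compounds named here.

Measured compounds:
compound 1 `CC(C)c1cc2c(cc1NS(=O)(=O)c1ccc(-c3ccc(Cl)cc3)cc1)CCN(C)CC2` — 12.6 nM
compound 2 `Cc1ccc(-c2ccc(S(=O)(=O)Nc3ccc4c(c3)CCN(C)CC4)cc2)s1` — 6.31 nM
compound 3 `CCCCc1ccc(S(=O)(=O)Nc2ccc3c(c2)CN(C)C3)cc1` — 5.01 nM

All three were tested in an assay on isolated protein for displacement of a labelled ligand from 5-hydroxytryptamine receptor 6 (Homo sapiens), read by radioligand binding; on this read-out higher numbers stand for weaker inhibition and lower numbers for stronger inhibition. Among these numbers, compound 1 has the highest one. Compound 2 is the nearest to it, and the gap between the two lies within the usual scatter of this assay, so nothing can be said about which of them inhibits more strongly. Compound 3 is the furthest away, and that gap is beyond the scatter, so compound 3 does give a lower number than compound 1.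

Among the measured compounds shown here, none of the measured compounds differ from one another in a single place, so no step of a known size is available to lean on. Compound 4 `CN1CCc2cc(Br)c(NS(=O)(=O)c3ccc(-c4ccc(Cl)cc4)cc3)cc2CC1` has not yet been measured. It differs from compound 1 in one place: bromo in place of isopropyl on an aromatic carbon.

For the measured compounds named here, with no comparable step to draw on, the expectation rests on the numbers alone. A change of this kind is expected to move this assay only a little, if at all, most likely toward a somewhat lower number but not beyond the scatter. Compound 4 is therefore estimated at 8 nM, with a range from 3 nM to 25 nM. That estimate means a step of a 1.6-fold lower number from compound 1 to compound 4 (0.20 log units; within the scatter) is expected.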

Compound 4, inhibition constant: 50.1 nM
Compound 4: middle estimate off by 6.3-fold (0.80 log units), on the low side, outside the stated range (above it).
By their numbers in this assay, from the lowest: compounds 3, 2 and 1 (each within the scatter of the next, the first and the last beyond it); then compound 4.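

Putting bromo in place of isopropyl on this aromatic carbon, ortho to a large group, gives a 4.0-fold higher number from compound 1 to compound 4 (0.60 log units; beyond the scatter) in this assay. Among the compounds shown here, this is the first single-place comparison in the set, and because the step is beyond the scatter, it shows that the group at this position matters to the read-out and that bromo and isopropyl cannot be treated as interchangeable here. The swap takes out a group of three carbons and puts in a single bromine, with no hydrogen-bond donors or acceptors and no net charge on either side, and no measurement here explains why the number goes up.

A single swap cannot separate the effect of losing isopropyl from that of gaining bromo, so a methyl, a methoxy or an amine on the same carbon would be needed to show how the number follows the group placed there. On these data alone, whether the same swap gives a step of similar size when the rest of the molecule is different also remains open.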